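This account rests on a few compounds, and the source may have more. Where it says the series, first, only, none or still open, it means among the compounds named here.

Compound 1, `Cc1ccc(S(=O)(=O)Oc2ccc3c(c2)C(=O)C=CC3=O)cc1`, in an assay on isolated protein for inhibition of DNA topoisomerase 1 (Homo sapiens); a lower number here means a stronger inhibitor, a higher number a weaker inhibitor: > 100000 nM, a limit of the assay rather than a number.
Compound 2, `O=C1C=CC(=O)c2cc(Oc3ccco3)ccc21`, in this assay: > 100000 nM, again a limit.
Compound 3, `CC(=O)Oc1ccc2c(c1)C(=O)C=CC2=O`, in this assay: > 100000 nM, again a limit.

All three measured compounds share one core and differ only in the group attached through an oxygen on an aromatic ring. None of them gave a readable number: every value shown sits at the limit of > 100000 nM in this assay, at which 3 of the 3 values shown sit, so compound 3 cannot be placed relative to its neighbours, only said to be no stronger than that limit. Within the data shown here, the one step between measured compounds, a step that the two limits leave unreadable from compound 2 to compound 3, is therefore unreadable in size and direction.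

Compound 4, `O=C1C=CC(=O)c2cc(Oc3cccs3)ccc21`, has not yet been measured. It differs from compound 3 in that (thiophen-2-yl in place of acetyl on an oxygen on an aromatic ring). Among the measured compounds shown here, no measured step bears readably on this change, since the exchange of a furan-2-yl for an acetyl left both ends at the limit. The expectation for the step from compound 3 to compound 4 is accordingly none beyond the scatter, written as a number no higher from compound 3 to compound 4 (the limit leaves the size open). Compound 4 is estimated at 100000 nM, within a range from 30000 nM to 300000 nM, and most probably the assay will again report only a limit.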

Compound 4, half-maximal inhibitory concentration: > 100000 nM
Compound 4: no number, only a limit (the forecaster's own chance of this, stated with the estimate: 85%); the middle value lies on the limit itself.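

In this assay compound 4 gives > 100000 nM as a limit of the assay and not a number. The steps to compound 4 from compound 2 and compound 3 therefore cannot be read in size or direction: the limit of > 100000 nM in this assay, at which 4 of the 4 values shown sit. The compounds shown leave open whether any group on this oxygen gives a readable inhibition, and how these groups rank against one another.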